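Replacing 3-fluorophenyl with 1H-pyrrol-2-yl in compound 3

This account rests on a few compounds, and the source may have more. Where it says the series, first, only, none or still open, it means among the compounds named here.

Values measured in a functional assay on HepG2 cells (Homo sapiens) for inhibition, read by sulforhodamine B assay, with a stated time of 3 days (on this read-out higher numbers stand for weaker inhibition and lower numbers for stronger inhibition), are as follows.
- Compound 1 `O=C1Nc2ccc(F)cc2/C1=C\C(=O)c1ccc(O)cc1F` gives 3440 nM in this test
- Compound 2 `O=C1Nc2ccc([N+](=O)[O-])cc2/C1=C\C(=O)c1ccc(C2CCCCC2)cc1` gives 3990 nM in this test
- Compound 3 `CN1CCN(c2cccc(N/C=C3\C(=O)Nc4ccc(NC(=O)c5cccc(F)c5)cc43)c2)CC1` gives 6720 nM in this test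

Compound 3 stands within the scatter of both other compounds, so the three values cannot be ranked. Compound 4 `CN1CCN(c2cccc(N/C=C3\C(=O)Nc4ccc(NC(=O)c5ccc[nH]5)cc43)c2)CC1` has 1H-pyrrol-2-yl in place of 3-fluorophenyl on a carbonyl carbon. Within the data shown here, no measured pair isolates a single change, so no step beyond the scatter is expected, and no firm direction. This expectation rests only on compound 2 at 3990 nM and compound 1 at 3440 nM lying so close to compound 3 despite their different structures. The estimated change is a 1.3-fold lower number from compound 3 to compound 4 (0.13 log units; within the scatter) and stays small. The value expected for compound 4 is 5000 nM, with an estimated range of 1500 nM to 16000 nM in this assay once measured.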

Compound 4, half-maximal inhibitory concentration: 5370 nM
Compound 4: the middle estimate sits 1.1-fold (0.03 log units) below what was measured; low and high end bracket the measured number.
By their numbers in this assay, from the lowest: compounds 1, 2, 4 and 3 (each within the scatter of the next).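

In this assay, among these compounds, the one pair differing in a single place gives a 1.3-fold lower number from compound 3 to compound 4 (0.10 log units; within the scatter), which lies within the scatter. On this carbonyl carbon, a five-membered aromatic ring with a hydrogen-bond donor therefore takes the place of 3-fluorophenyl with no readable change in the number. Nothing available explains this result. Still open, going by these compounds, is whether an aliphatic amine or a carboxylic acid on this carbonyl carbon would stay within the scatter of compound 3 . Also open, on these data alone, is whether a longer alkyl chain there would do the same.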